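Adding a second chloro to compound 2

The source may hold more compounds than are shown below. What is called first, only, known or untested is meant among the compounds shown, and "the series" means these compounds.

In a functional assay on Jurkat cells (Homo sapiens) for inhibition, with a stated time of 24 h (a lower number here means a stronger inhibitor, a higher number a weaker inhibitor), compound 1 `O=[N+]([O-])c1ccc(Nc2nnc(-c3c[nH]c4ccccc34)o2)cc1` gives 45000 nM, and compound 2 `Clc1ccc(Nc2nnc(-c3c[nH]c4ccccc34)o2)cc1` gives 30200 nM. These two values sit within the usual scatter of each other. Among the measured compounds shown here, the only measured step, a 1.5-fold lower number from compound 1 to compound 2 (0.17 log units; within the scatter), put chloro in place of nitro. Compound 3 `Clc1ccc(Nc2nnc(-c3c[nH]c4ccccc34)o2)cc1Cl` differs from compound 2 by chloro in place of hydrogen on an aromatic carbon, ortho to a chloro group. That single step is a thin guide, so little movement is expected in this assay, and the expected step is a 1.2-fold lower number from compound 2 to compound 3 (0.08 log units; within the scatter). For compound 3, the estimated value is 25000 nM, with a range of 10000 nM to 60000 nM.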

Compound 3, half-maximal inhibitory concentration: > 100000 nM
Compound 3 gave a limit, no number (the forecaster's own chance of this, stated with the estimate: 15%); at least 4.0-fold (0.60 log units) between middle value and limit.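

In this assay, a chloro placed ortho to a chloro group on this ring is not a neutral change: it gives an at least 3.3-fold higher number from compound 2 to compound 3 (0.51 log units; beyond the scatter). The earlier swap of nitro for chloro stayed within the scatter, so this is the first change shown that moves the number beyond it. Compound 3 stands at a limit of the assay and not at a number, so the full size of the step stays unknown: the limit of > 100000 nM in this assay, at which 1 of the 3 values shown sits.

Open, from the compounds shown here alone, is whether fluoro, methyl or an amine at this position would also raise the number. Also open, going by these compounds, is whether chloro at another place on this ring would do the same.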